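The source may report more compounds than this note shows. Statements on the series, on what has been measured and on what is new or still open speak of the compounds shown alone.

Measured compounds:
Compound 1 `Cn1ccc2ccc(-c3cc(Nc4ccccc4S(=O)(=O)Nc4cncnc4)cc4nccnc34)cc21`: > 100000 nM
Compound 2 `CN(C)C(=O)c1ccncc1Nc1cc(-c2ccc3ccn(C)c3c2)c2nccnc2c1`: > 100000 nM

In an assay on lysate for inhibition of 6-phosphofructo-2-kinase/fructose-2,6-bisphosphatase 3 (Homo sapiens), with stated times of 0.5 min and 45 min (a higher number here means a weaker inhibitor, a lower number a stronger inhibitor), compound 1 gives > 100000 nM, a limit of the assay rather than a number. Compound 2 likewise gives > 100000 nM, again a limit and not a number. Compound 2 therefore stands at the limit of > 100000 nM in this assay, at which 2 of the 2 values shown sit, and nothing measured here separates it from compound 1.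

Compound 3 `CC(=O)N1CCCC(NC(=O)c2ccncc2Nc2cc(-c3ccc4ccn(C)c4c3)c3nccnc3c2)C1` has not yet been measured. It differs from compound 2 in one place: (1-acetylpiperidin-3-yl)amino in place of dimethylamino on a carbonyl carbon. Read one bond further out, the change is (1-acetylpiperidin-3-yl)carbamoyl in place of dimethylcarbamoyl, on a carbonyl carbon whose other neighbour is an aromatic carbon. Going by the values given here, since compound 2 sits at a limit, no measured step can be drawn from it; the expected step from compound 2 to compound 3 in this assay is a number no higher from compound 2 to compound 3 (the limit leaves the size open), none beyond the scatter. Compound 3 is accordingly estimated at about 100000 nM, within 20000 nM to 300000 nM, most likely again reported only as a limit.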

Compound 3, half-maximal inhibitory concentration: 13500 nM
Beside the measured number, compound 3's estimate is 7.4-fold (0.87 log units) above it, outside the stated range (below it).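

In this assay, the group on the carbonyl carbon proves to be a place where the read-out can move: (1-acetylpiperidin-3-yl)amino in place of dimethylamino gives an at least 7.4-fold lower number from compound 2 to compound 3 (0.86 log units; beyond the scatter). Compound 3 is the first compound shown that gives a number rather than a limit, which shows that the shared core can register in this assay once this group is changed. The true size of the step stays open, as the value for compound 2 is a limit and not a number: the limit of > 100000 nM in this assay, at which 2 of the 3 values shown sit.

The compounds shown leave open which part of the entering group carries the step: the acetyl group, the piperidine ring or the amide hydrogen. They also do not tell whether a free amine in place of the acetyl group, or an open alkyl chain in place of the ring, would keep the value of compound 3 at 13500 nM.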